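Oxygen to Sulfur Linker Swap on a Diamine Core

The compounds below may be only part of what the source reports. "The series", "measured", "known", "first", "only" and "open" are said of these compounds alone.

Measured so far:
compound 1 `COc1ccc(Sc2nc3cc(N)cc(N)c3nc2-c2ccccc2)cc1`, 69200 nM
compound 2 `Nc1cc(N)c2nc(-c3ccccc3)c(Sc3ccc(Cl)c(Cl)c3)nc2c1`, 9770 nM
compound 3 `Nc1cc(N)c2nc(-c3ccccc3)c(Oc3ccc(F)cc3)nc2c1`, < 100000 nM

The three compounds were tested in a functional assay on DU-145 cells (Homo sapiens) for inhibition, read by sulforhodamine B assay, with a stated time of 48 h; on this read-out higher numbers stand for lower toxicity in this test and lower numbers for higher toxicity in this test. In this assay compound 1 gives 69200 nM and compound 2 gives 9770 nM, a change of a 7.1-fold lower number from compound 1 to compound 2 (0.85 log units; beyond the scatter). For compound 3 the assay reports only a limit, < 100000 nM, so the steps a step that the limit leaves unreadable from compound 1 to compound 3 and a step that the limit leaves unreadable from compound 2 to compound 3 cannot be read, as noted in the limit of < 100000 nM in this assay, at which 1 of the 3 values shown sits.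

Compound 4 `Nc1cc(N)c2nc(-c3ccccc3)c(Sc3ccc(F)cc3)nc2c1` differs from compound 3 by (4-fluorophenyl)sulfanyl in place of 4-fluorophenoxy on an aromatic carbon. Within the data shown here, no measured step tests this oxygen-to-sulfur exchange on its own. Compound 4 is therefore expected near the two sulfur-linked compounds, with a step that the limit leaves unreadable from compound 3 to compound 4 unreadable against a limit, and an estimated value of 30000 nM within the range 8000 nM to 100000 nM.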

Compound 4, concentration lethal to 50% of the cells: < 100000 nM
Compound 4 was reported as a limit; the forecaster's own chance of this, stated with the estimate: 20%; the middle value lies beyond the limit too.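

No step from compound 1, compound 2 or compound 3 to compound 4 can be read, because compound 4 is reported only as a limit: the limit of < 100000 nM in this assay, at which 2 of the 4 values shown sit.

From the compounds shown here alone, whether exchanging the oxygen linker for sulfur changes the result in this assay stays open.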